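The compounds below may be only part of what the source reports. "The series", "measured", "known", "first", "only" and "open" are said of these compounds alone.

Measured in a functional assay on A2780 cells (Homo sapiens) for antiproliferative activity, read by MTT assay, with a stated time of 72 h; a lower number here means a stronger inhibitor, a higher number a weaker inhibitor:
- Compound 1 `O=C(c1cc2ccccc2o1)N1N=C(c2ccc(F)cc2)CC1c1ccccc1`: 11.8 ug/mL
- Compound 2 `O=C(c1cc2ccccc2o1)N1N=C(c2ccc(F)cc2)CC1c1ccc([N+](=O)[O-])cc1`: > 50 ug/mL, a limit of the assay rather than a number
- Compound 3 `O=C(c1cc2ccccc2o1)N1N=C(c2ccc(F)cc2)CC1c1ccccc1Cl`: 45.2 ug/mL

Of the two exact numbers, compound 3 holds the higher. Compound 4 `O=C(c1cc2ccccc2o1)N1N=C(c2ccc(F)cc2)CC1c1ccc(F)cc1` carries 4-fluorophenyl in place of 2-chlorophenyl on a saturated ring carbon. Among the measured compounds shown here, two measured steps bear on this. Replacing a hydrogen on the aromatic ring of compound 1 raised the number both times, an at least 4.2-fold higher number from compound 1 to compound 2 (0.62 log units; beyond the scatter) and a 3.8-fold higher number from compound 1 to compound 3 (0.58 log units; beyond the scatter). No fluoro group on that ring has been measured. Compound 4 is expected to sit between compound 1 and compound 3, a modest expected step of a 2.3-fold lower number from compound 3 to compound 4 (0.35 log units; beyond the scatter) in this assay. Compound 4 is estimated at 20 ug/mL, with an expected range of 8 ug/mL to 50 ug/mL.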

Compound 4, half-maximal inhibitory concentration: > 50 ug/mL
Compound 4 gave a limit, no number (the forecaster's own chance of this, stated with the estimate: 12%); middle value at least 2.5-fold (0.39 log units) from the limit.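

In this assay, a fluoro group in place of hydrogen on this aromatic ring also raises the number, an at least 4.2-fold higher number from compound 1 to compound 4 (0.62 log units; beyond the scatter), so all three groups shown on this ring move the same way. Against the 2-chlorophenyl group, the 4-fluorophenyl group shows no separation beyond the scatter, an at least 1.1-fold higher number from compound 3 to compound 4 (0.04 log units; that floor lies within the scatter). The step between the nitro and fluoro compounds cannot be read, because both stop at a limit rather than a number: the limit of > 50 ug/mL in this assay, at which 2 of the 4 values shown sit.

Going by these compounds, how far compound 2 and compound 4 lie past that limit stays open. So does whether a methoxy group or an amine on this ring would keep the number of compound 1.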